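A few compounds are considered here, and "the series" means these few. Any claim that something is new, unique, unknown or untested is made for them only; others in the source may bear on it.

Compound 3 `CCc1ccc(S(=O)(=O)NC(=O)Nc2ccc(Cl)cc2)s1` gives 89% in a functional assay on the whole organism (6C3HED cells, Mus musculus) for inhibition, at a dose of 300 mg/kg by the oral route (on this read-out higher numbers stand for more inhibition at the one dose given (going by the name of the read-out) and lower numbers for less inhibition), the second highest of the three measured numbers: compound 2 `COc1ccc(S(=O)(=O)NC(=O)Nc2ccc(Cl)cc2)s1` gives 100%, and compound 1 `O=C(Nc1ccc(Cl)cc1)NS(=O)(=O)c1cccs1` gives 66%. Compound 4 `CCCOc1ccc(S(=O)(=O)NC(=O)Nc2ccc(Cl)cc2)s1` differs from compound 3 by propoxy in place of ethyl on an aromatic carbon. Going by the values given here, three measured steps bear on this change: a number 34 percentage points higher from compound 1 to compound 2 (beyond the scatter), a number 23 percentage points higher from compound 1 to compound 3 (beyond the scatter) and a number 11 percentage points lower from compound 2 to compound 3 (beyond the scatter), so the number for the group bearing an oxygen stood above that for ethyl, and both stood above that for hydrogen. Among the compounds with values here, because the step of a number 11 percentage points lower from compound 2 to compound 3 (beyond the scatter) shows a higher number for the oxygen-bearing group, a modest rise is expected for compound 4, though no measured compound carries a chain of this length, so the expected step is a number 5 percentage points higher from compound 3 to compound 4 (within the scatter). Compound 4 is therefore estimated to give 94%, within 78% to 100%.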

Compound 4, a percentage reported as inhibition, in the whole organism at one dose (the size of the read-out at that dose, not a potency): 63%
Compound 4: middle estimate off by 31 percentage points, on the high side, and the stated range ends above it.
By their numbers in this assay, from the lowest: compounds 4 and 1 (each within the scatter of the next); then compound 3; then compound 2.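

In this assay, an oxygen-bearing group at this position does not by itself keep the number high: propoxy in place of ethyl gives a number 26 percentage points lower from compound 3 to compound 4 (beyond the scatter), and ethyl in place of hydrogen on the saturated chain carbon bound to the oxygen gives a number 37 percentage points lower from compound 2 to compound 4 (beyond the scatter). Propoxy in place of hydrogen gives a number 3 percentage points lower from compound 1 to compound 4 (within the scatter), so the gain seen with methoxy and with ethyl at this position is absent with propoxy. Nothing available explains this fall. The compounds shown leave open how ethoxy, a longer chain or an amine at this position would read out, and so whether the number falls gradually or abruptly as the chain grows.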